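Swapping the Chain End for a Phenoxy Group

The source may hold more compounds than are shown below. What is called first, only, known or untested is meant among the compounds shown, and "the series" means these compounds.

Compound 2 `CC(C)CCSc1nc(C(F)(F)F)ccc1CNC(=O)C(C)c1ccc(NS(C)(=O)=O)c(F)c1` gives 82 nM in an assay on CHO-K1 cells for antagonist activity at transient receptor potential cation channel subfamily V member 1 (Homo sapiens), read by FLIPR (a higher number here means a weaker inhibitor, a lower number a stronger inhibitor), and compound 1 `CCCCCSc1nc(C(F)(F)F)ccc1CNC(=O)C(C)c1ccc(NS(C)(=O)=O)c(F)c1` gives 95.6 nM; the two numbers sit within the scatter of each other, as the step of a 1.2-fold lower number from compound 1 to compound 2 (0.07 log units; within the scatter) shows. Compound 3 `CC(C(=O)NCc1ccc(C(F)(F)F)nc1SCCOc1ccccc1)c1ccc(NS(C)(=O)=O)c(F)c1`, not yet measured, carries phenoxy in place of isopropyl on a saturated chain carbon, two bonds along the chain from a sulfur. Going by the values given here, the one measured step at this place, a 1.2-fold lower number from compound 1 to compound 2 (0.07 log units; within the scatter), changed little, but the aromatic ring and oxygen that enter now are a larger alteration with no measured precedent here. The expected step of a 1.3-fold higher number from compound 2 to compound 3 (0.13 log units; within the scatter) is therefore modest, and compound 3 is estimated at 110 nM, with a range from 35 nM to 350 nM.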

Compound 3, half-maximal inhibitory concentration: 118 nM
Beside the measured number, compound 3's estimate is 1.1-fold (0.03 log units) below it; low and high end bracket the measured number.
By their numbers in this assay, from the lowest: compounds 2, 1 and 3 (each within the scatter of the next).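

At this place, on a saturated chain carbon, two bonds along the chain from a sulfur, phenoxy brings a six-membered aromatic ring and an oxygen, yet a 1.4-fold higher number from compound 2 to compound 3 (0.16 log units; within the scatter) and a 1.2-fold higher number from compound 1 to compound 3 (0.09 log units; within the scatter) in this assay both stay within the scatter. The seven heavy atoms of phenoxy, against the three of isopropyl, therefore leave no readable difference in this assay. No evidence here accounts for this result. Still open, as far as these compounds go, is how an amine or a carboxylic acid at this place would read, and whether a longer chain carrying the phenoxy would do the same.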